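Isopropyl to methyl on the amide of compound 2

The source may report more compounds than this note shows. Statements on the series, on what has been measured and on what is new or still open speak of the compounds shown alone.

Within the data shown here, in a functional assay on HCT-116 cells (Homo sapiens) for antiproliferative activity, read by sulforhodamine B assay, with a stated time of 4 days (a lower number here means a stronger inhibitor of growth, a higher number a weaker inhibitor of growth), compound 1 (`COc1cc(Cl)c(-c2nc(SCC(=O)NC(C)C)nc3[nH]cc(C#N)c23)cc1O`) gives 238 nM and compound 2 (`COc1cc(Cl)c(-c2nc(SCC(=O)NC(C)C)nc3[nH]cc(C#N)c23)cc1OC`) gives 81 nM as the lower of the two numbers so far. Among the measured compounds shown here, the only measured step (a 2.9-fold lower number from compound 1 to compound 2 (0.47 log units; beyond the scatter)) is modest and comes from methyl in place of hydrogen on an oxygen on an aromatic ring. Compound 3 (`CNC(=O)CSc1nc(-c2cc(OC)c(OC)cc2Cl)c2c(C#N)c[nH]c2n1`) leaves that ring as in compound 2 and instead carries methyl in place of isopropyl on an amide-type nitrogen. For the measured compounds named here, no measurement yet covers a change on this nitrogen, so the one measured step offers no guide to size or direction here. The expected step (a 1.4-fold higher number from compound 2 to compound 3 (0.13 log units; within the scatter)) stays within the scatter in this assay as a working assumption, with a wide margin on both sides. For compound 3 the estimated value is 110 nM with an expected range from 35 nM to 350 nM pending measurement.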

Compound 3, concentration for 50% growth inhibition: 42 nM
Compound 3: middle estimate off by 2.6-fold (0.42 log units), on the high side; low and high end bracket the measured number.
By their numbers in this assay, from the lowest: compounds 3 and 2 (each within the scatter of the next); then compound 1.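

In this assay, among these compounds, methyl in place of isopropyl on the amide-type nitrogen gives a 1.9-fold lower number from compound 2 to compound 3 (0.29 log units; within the scatter), the first measured step at this position. Isopropyl and methyl therefore read alike on this nitrogen when the ring carries the two methoxy groups of compound 2, so the size of the isopropyl group is not needed to hold a number of this order in this assay. No other measurement here bears on the reason for this result.

Still open, going by these compounds, is how a longer chain, a phenyl ring or a chain ending in an amine or a carboxylic acid would read on this nitrogen. The compounds shown also leave open whether the methyl and isopropyl groups would still read alike with the hydroxy group of compound 1 on the ring.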